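Replacing the side chain on the amine of compound 1

The source may hold more compounds than are shown below. What is called first, only, known or untested is meant among the compounds shown, and "the series" means these compounds.

- compound 1 `Cc1cn([C@@H]2O[C@H](CO[Si](C)(C)C(C)(C)C)[C@@]3(OS(=O)(=O)C=C3NCC(=O)C(=O)N3CCC3)[C@H]2O[Si](C)(C)C(C)(C)C)c(=O)n(C)c1=O`: 84400 nM
- compound 2 `COC(=O)CNC1=CS(=O)(=O)O[C@@]12[C@@H](CO[Si](C)(C)C(C)(C)C)O[C@@H](n1cc(C)c(=O)n(C)c1=O)[C@@H]2O[Si](C)(C)C(C)(C)C`: 160000 nM

In a functional assay on HEL cells (Homo sapiens) (on this read-out lower numbers stand for higher toxicity in this test and higher numbers for lower toxicity in this test), compound 1 gives 84400 nM and compound 2 gives 160000 nM. These two values lie within the usual scatter of each other, so neither can be ranked above the other. For the measured compounds named here, the single measured step, a 1.9-fold higher number from compound 1 to compound 2 (0.28 log units; within the scatter), puts methoxy in place of (azetidin-1-yl)carbonyl on a carbonyl carbon.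

The next compound is compound 3 `CCOC(=O)CNC(=O)NC1=CS(=O)(=O)O[C@@]12[C@@H](CO[Si](C)(C)C(C)(C)C)O[C@@H](n1cc(C)c(=O)n(C)c1=O)[C@@H]2O[Si](C)(C)C(C)(C)C`, and the change from compound 1 is larger: ((ethoxycarbonyl)methyl)carbamoyl in place of (((azetidin-1-yl)carbonyl)carbonyl)methyl on an amine nitrogen. In words, ((ethoxycarbonyl)methyl)carbamoyl stands in place of (((azetidin-1-yl)carbonyl)carbonyl)methyl on an amine nitrogen. Going by the values given here, no measured step shows what this exact swap does, so the measured step above is the only guide, and it stayed within the scatter. No shift beyond the scatter is therefore expected in this assay. The expected change is a 1.3-fold higher number from compound 1 to compound 3 (0.12 log units; within the scatter). Compound 3 is estimated at 110000 nM, with an expected range of 45000 nM to 260000 nM.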

Compound 3, half-maximal cytotoxic concentration: 13000 nM
For compound 3 the middle estimate is 8.5-fold (0.93 log units) above the measured one; the whole stated range lies above it.
By their numbers in this assay, from the lowest: compound 3; then compounds 1 and 2 (each within the scatter of the next).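

In this assay the group on the amine nitrogen clearly matters: ((ethoxycarbonyl)methyl)carbamoyl in place of (((azetidin-1-yl)carbonyl)carbonyl)methyl gives a 6.5-fold lower number from compound 1 to compound 3 (0.81 log units; beyond the scatter) and, in place of (methoxycarbonyl)methyl, gives a 12-fold lower number from compound 2 to compound 3 (1.09 log units; beyond the scatter) with both steps beyond the scatter. For the compounds shown here, the earlier change on a carbonyl carbon stayed within the scatter, so these are the first steps to show a real rise in toxicity in this test. Nothing available explains this shift.

The compounds shown cannot tell whether the carbamoyl unit itself or the ethyl ester at the end of the chain accounts for the step. A carbamoyl group carrying a carboxylic acid, an amine or a longer chain in place of the ethoxycarbonyl end remains an open case.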